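Extending the amide phenyl of compound 2

The source may hold more compounds than are shown below. What is called first, only, known or untested is meant among the compounds shown, and "the series" means these compounds.

Compound 1 `Cn1cc(-c2ccncc2/C=C/C(N)=O)cn1` and compound 2 `Cn1cc(-c2ccncc2/C=C/C(=O)Nc2ccccc2)cn1` share one core with an unsaturated amide at its end. In an assay on cells for inhibition of cyclin-dependent kinase 8 (Homo sapiens), with stated times of 2 h and 1 h (a lower number here means that less compound is needed, a higher number that more compound is needed for the effect), compound 1 gives > 10000 nM, which is a limit of the assay and not a number. In this assay compound 2 gives 110 nM. Among the compounds with values here, the step of an at least 90-fold lower number from compound 1 to compound 2 (1.95 log units; beyond the scatter) is the only measured step, so compound 2 holds the only number in this assay. Compound 1 sits at the limit of > 10000 nM in this assay, at which 1 of the 2 values shown sits.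

Compound 3 `Cn1cc(-c2ccncc2/C=C/C(=O)Nc2ccc(CN3CC4CC3CO4)cc2)cn1` differs from compound 2 by a group of 8 heavy atoms (6 carbon, 1 nitrogen, 1 oxygen; 2 five-membered non-aromatic rings with 1 hetero atom each) in place of a hydrogen atom, on an aromatic carbon. Within the data shown here, the measured step changed the amide nitrogen substituent itself, whereas the present change keeps the phenyl and builds onto it, so no measured step bears on it directly and the large size of that step cannot be carried over. The expected step is a 2.0-fold lower number from compound 2 to compound 3 (0.30 log units; within the scatter), a small movement toward a lower number that stays within the scatter. Compound 3 is estimated at 55 nM, with a range from 12 nM to 300 nM.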

Compound 3, half-maximal effective concentration: 19 nM
Compound 3: middle estimate off by 2.9-fold (0.46 log units), on the high side; low and high end bracket the measured number.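

Building onto the phenyl, rather than replacing the substituent on the amide nitrogen, still moves the number in this assay: the step is a 5.8-fold lower number from compound 2 to compound 3 (0.76 log units; beyond the scatter) and it is the first one in the series measured between two real numbers. The aromatic carbon para to a large group therefore accepts a group of 8 heavy atoms, with 2 five-membered non-aromatic rings, and the number falls rather than rises, whereas earlier only hydrogen had been seen at this position. No measured information shown here bears on why the number falls with this group.

From the compounds shown here alone, it remains open whether the step needs both rings of the group or only its nitrogen, which a simple dimethylaminomethyl group at the same position would test. A carboxylic acid there would show whether a group without that nitrogen is accepted as well.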